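Acetylation of the aminomethyl side chain in compound 4

The source may report more compounds than this note shows. Statements on the series, on what has been measured and on what is new or still open speak of the compounds shown alone.

Compound 1 `C[C@H](O)[C@H]1C(=O)N2C(C(=O)O)=C(C(C)(C)C)O[C@H]12`: 7.1 h
Compound 2 `COC(=O)[C@H](O)[C@H]1C(=O)N2C(C(=O)O)=C(C(C)(C)C)O[C@H]12`: 6.7 h
Compound 3 `CC(C)(C)C1=C(C(=O)O)N2C(=O)[C@H](CN)[C@H]2O1`: 1.2 h

In an ADME assay, in phosphate buffer, at 28 degrees C, at pH 7.0 (on this read-out higher numbers stand for a longer-lived compound and lower numbers for a shorter-lived compound), compound 3 stands lowest of the three measured compounds. The change to compound 4 `CC(=O)NC[C@H]1C(=O)N2C(C(=O)O)=C(C(C)(C)C)O[C@H]12` is acetyl in place of hydrogen on an amine nitrogen. Going by the values given here, no measured step acylates an amine; the steps that bear on it are a 5.9-fold lower number from compound 1 to compound 3 (0.77 log units; beyond the scatter) and a 5.6-fold lower number from compound 2 to compound 3 (0.75 log units; beyond the scatter), both modest and both beyond the scatter, and compound 4 carries, like compound 1 and compound 2, a group with no net charge at that position. Compound 4 is therefore expected to move back toward those two, by a modest step of a 2.9-fold higher number from compound 3 to compound 4 (0.46 log units; beyond the scatter), though the absence of a matching step keeps the range wide. Compound 4 is estimated at 3.5 h, between 1.4 h and 8.5 h.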

Compound 4, half-life: < 3 h
Compound 4 was reported as a limit; the forecaster's own chance of this, stated with the estimate: 0%; at least 1.1-fold (0.06 log units) between middle value and limit.
By their numbers in this assay, from the lowest: compound 3; then compounds 2 and 1 (each within the scatter of the next).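

Compound 4 is reported only as a limit in this assay: the limit of < 3 h in this assay, at which 1 of the 4 values shown sits.

Even so, acetamidomethyl on the saturated ring carbon, with no net charge, does not match the two hydroxy-bearing side chains, giving an at least 2.2-fold lower number from compound 2 to compound 4 (0.34 log units; beyond the scatter) and an at least 2.3-fold lower number from compound 1 to compound 4 (0.37 log units; beyond the scatter). The step that acetylation itself makes from the aminomethyl compound, compound 3, cannot be read.

Going by these compounds, it therefore remains open whether acetyl on the amine nitrogen changes the half-life at all. On these data alone, it also remains open whether a hydroxymethyl chain on this ring carbon, or a propionyl group on the amine nitrogen, would stand with compound 1 and compound 2 or nearer compound 3.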